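Extending an Ethoxy Chain by One Carbon

The compounds below may be only part of what the source reports. "The series", "measured", "known", "first", "only" and "open" are said of these compounds alone.

Among the compounds with values here, compound 1 `CCOc1cc(C)c(-c2cccc(CNc3ccc(OCC(=O)O)c(F)c3)c2)c(C)c1` is the only compound in this set with a number. In a physicochemical assay for lipophilicity, read by HPLC, in phosphate buffer, measured as octanol-water partition, at pH 7.4, tested at 100 uM (a higher number here means a more lipophilic compound, a lower number a more polar compound), compound 1 gives 3.04, and since no second value is available for comparison, it stands alone rather than high or low against anything. Compound 2 `CCOc1cc(C)c(-c2cccc(CNc3ccc(OCC(=O)O)cc3)c2)c(C)c1` has in this assay only the entry "not determined" (no result reported), so nothing can be drawn from it.

Compound 3 `CCCOc1cc(C)c(-c2cccc(CNc3ccc(OCC(=O)O)c(F)c3)c2)c(C)c1` is still to be measured in this assay. It differs from compound 1 by a single small change: methyl in place of hydrogen on a saturated chain carbon, two bonds along the chain from an oxygen on an aromatic ring. Put another way, an ethoxy group becomes a propoxy group.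

Within the data shown here, no step between two measured compounds exists here to calibrate this change, so the expectation rests on the change itself and on the value of compound 1. A modest rise, beyond the usual scatter but not large, is expected, and the expected step is a number 0.41 log units higher from compound 1 to compound 3 (beyond the scatter). Compound 3 is therefore estimated to give 3.45, with a range from 3.15 to 3.8.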

Compound 3, distribution coefficient: 3.59
Beside the measured number, compound 3's estimate is 0.14 log units below it, within the range that was stated.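

Within the data shown here, measured in this assay the change from ethoxy to propoxy gives a number 0.55 log units higher from compound 1 to compound 3 (beyond the scatter) and this is the first comparison the set allows, since compound 1 previously stood alone with no second number to set against it. The step is modest in size but lies clear of the ordinary variation between repeated measurements, so this position on the chain does register the added methyl, at least for this one pair of compounds. No measured evidence accompanies the result to account for the size of the step, and a single pair sets no rule for other chains or other parts of the molecule.

A single step cannot show whether a butoxy chain would raise the number further in the same measure, or whether a methoxy group would lower it by a similar amount. Also open, as far as these compounds go, is how a branched isopropoxy group, or an amine or a hydroxyl group placed on this same chain, would read in this assay when compared with the plain ethoxy and propoxy chains.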